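Swapping the Amide Heteroaryl Ring in a Triazole Series

The compounds below may be only part of what the source reports. "The series", "measured", "known", "first", "only" and "open" are said of these compounds alone.

Compound 1 `Cc1cc(NC(=O)Cn2cc(-c3ccc(F)cc3)nn2)no1`: in a functional assay on BMDM cells (Mus musculus, strain C57BL/6) for inhibition, with a stated time of 2 days (a higher number here means a weaker inhibitor, a lower number a stronger inhibitor), compound 1 gives > 30000 nM, which is a limit of the assay.
Compound 2 `Cc1cc(NC(=O)Cn2cc(-c3cccc(Cl)c3)nn2)no1`: in this assay compound 2 gives > 30000 nM, also a limit of the assay.
Compound 3 `Cc1cc(NC(=O)Cn2cc(-c3ccc(C#N)cc3)nn2)no1`: in this assay compound 3 gives 9320 nM.

Compound 1 therefore stands at the edge of what the assay reports, as shown by the limit of > 30000 nM in this assay, at which 2 of the 3 values shown sit. The two measured steps both alter the aryl group attached to the triazole: a step that the two limits leave unreadable from compound 1 to compound 2 and an at least 3.2-fold lower number from compound 1 to compound 3 (0.50 log units; beyond the scatter). Compound 4 `Cc1csc(NC(=O)Cn2cc(-c3ccc(F)cc3)nn2)n1` changes a different part of the molecule: 4-methyl-1,3-thiazol-2-yl in place of 5-methyl-1,2-oxazol-3-yl on an amide-type nitrogen. Neither measured step touches the amide heteroaryl ring, so no measured step bears directly on this change, and nothing in the data gives a reason to expect a step beyond the scatter in this assay in either direction. Compound 4 is therefore expected to sit near the limit, at about 30000 nM. The range for compound 4 is estimated to run from 10000 nM to 100000 nM. This corresponds to an expected step of a number no higher from compound 1 to compound 4 (the limit leaves the size open).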

Compound 4, half-maximal inhibitory concentration: 250 nM
The estimate for compound 4 lay 120-fold (2.08 log units) above the measured number, outside the stated range (below it).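

Among these compounds, the amide heteroaryl ring, which no earlier step touched, turns out to weigh heavily in this assay: 4-methyl-1,3-thiazol-2-yl in place of 5-methyl-1,2-oxazol-3-yl on the amide-type nitrogen gives an at least 120-fold lower number from compound 1 to compound 4 (2.07 log units; beyond the scatter). The two groups match in heavy-atom count and in hydrogen-bond donors and acceptors, so those counts do not separate them. The full size of the step stays open, as the value of compound 1 is only a limit: the limit of > 30000 nM in this assay, at which 2 of the 4 values shown sit.

The compounds shown leave open whether the 4-methyl-1,3-thiazol-2-yl group would bring a similar step when paired with the aryl groups of compound 2 or compound 3. They also leave open what would happen with a carboxylic acid or an ethyl group in place of the methyl group on that ring.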